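Sulfonamide Heterocycle Swap from Compound 2 to Compound 4

The source may report more compounds than this note shows. Statements on the series, on what has been measured and on what is new or still open speak of the compounds shown alone.

Compound 1, `Clc1ccc(C(/C=C/c2ccccc2)=N\Nc2nncc3ccccc23)cc1`: 5.7 nM
Compound 2, `Cc1cc(NS(=O)(=O)c2ccc(Nc3nncc4ccccc34)cc2)no1`: 43 nM
Compound 3, `COc1ccc(NC(=S)NNc2nncc3ccccc23)cc1`: 67 nM

All three were measured in a functional assay on COLO 205 cells (Homo sapiens) for antiproliferative activity, read by sulforhodamine B assay, with a stated time of 72 h; a lower number here means a stronger inhibitor, a higher number a weaker inhibitor. Among them compound 2 stands second highest; its number lies within the usual scatter of that of compound 3, while compound 1 sits beyond the scatter with a clearly lower number.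

Compound 4, `Cc1cc(C)nc(NS(=O)(=O)c2ccc(Nc3nncc4ccccc34)cc2)n1`, has not yet been measured. It differs from compound 2 at the sulfonamide nitrogen: 4,6-dimethylpyrimidin-2-yl in place of 5-methyl-1,2-oxazol-3-yl on a sulfonamide nitrogen. Within the data shown here, no measured pair shows a change of this kind, so there is no precedent to lean on. The step is expected to be small, a 1.2-fold higher number from compound 2 to compound 4 (0.07 log units; within the scatter), with no clear direction beyond the scatter. For compound 4 the estimate is 50 nM, between 15 nM and 160 nM.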

Compound 4, half-maximal inhibitory concentration: 7.9 nM
Beside the measured number, compound 4's estimate is 6.3-fold (0.80 log units) above it; measured number outside the range, below it.
By their numbers in this assay, from the lowest: compounds 1 and 4 (each within the scatter of the next); then compounds 2 and 3 (each within the scatter of the next).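

The group on the sulfonamide nitrogen turns out to matter: in this assay, 4,6-dimethylpyrimidin-2-yl in place of 5-methyl-1,2-oxazol-3-yl gives a 5.4-fold lower number from compound 2 to compound 4 (0.74 log units; beyond the scatter). Among these compounds, this is the first measured change at this position, and it shows that swapping one aromatic ring with two hetero atoms for another can move the number beyond the usual scatter. Nothing measured here explains the step.

Open, as far as these compounds go, is whether the step belongs to the six-membered ring or to its methyl groups, which a bare pyrimidin-2-yl would separate. An acetyl group on the same nitrogen would test whether a ring is needed at all.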